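The source may report more compounds than this note shows. Statements on the series, on what has been measured and on what is new or still open speak of the compounds shown alone.

Three compounds have been measured in an assay for inhibition of Indoleamine 2,3-dioxygenase 1 (Homo sapiens), read by spectrophotometry, with stated times of 1 h and 4 h; on this read-out lower numbers stand for stronger inhibition and higher numbers for weaker inhibition:

compound 3 `O=S(=O)(NNc1ccc(Br)cc1)c1ccc(Br)cc1` gives 85 nM;
compound 2 `CC(=O)Nc1ccc(S(=O)(=O)NNc2ccc(Cl)c(F)c2)cc1` gives 194 nM;
compound 1 `CC(=O)Nc1ccc(S(=O)(=O)NNc2ccc(C(F)(F)F)cc2)cc1` gives 1610 nM.

Compound 3 stands at the lowest number of the three. Compound 2 comes nearest to it, with a number beyond the scatter above it, and compound 1 lies furthest away, well beyond the scatter. Compound 4 `O=C(O)c1ccc(S(=O)(=O)NNc2ccc(Br)cc2)cc1` has not been measured yet. It differs from compound 3 in one place: carboxy in place of bromo on an aromatic carbon. Going by the values given here, no pair of measured compounds differs in exactly this way, so a step of this kind has not been seen. Compounds 1 and 2, which do not carry bromo on both rings, give higher numbers than compound 3, but each differs from it in more than one place, so their values say nothing direct about what a carboxy in this place does. In this assay the step from compound 3 to compound 4 is expected to be a 7.1-fold higher number from compound 3 to compound 4 (0.85 log units; beyond the scatter), toward weaker inhibition, with wide uncertainty. Compound 4 is estimated at 600 nM, within a range from 150 nM to 3000 nM.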

Compound 4, half-maximal inhibitory concentration: 61 nM
For compound 4 the middle estimate is 9.8-fold (0.99 log units) above the measured one, and the stated range ends above it.
By their numbers in this assay, from the lowest: compounds 4 and 3 (each within the scatter of the next); then compound 2; then compound 1.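

In this assay, putting a carboxy where the bromo stood on this aromatic carbon gives a 1.4-fold lower number from compound 3 to compound 4 (0.14 log units; within the scatter), so the two compounds cannot be told apart. For this one pair, the position para to a large group accepts a bigger group that brings a hydrogen-bond donor and acceptor in place of a single bromine atom, with no change beyond the scatter. Nothing shown here explains why the two groups read alike.

Going by these compounds, whether the position accepts other groups stays open, since a methyl ester, a primary amide or an amine on the same carbon would show whether the match is special to bromo and carboxy. It is also unknown whether the carboxy would still match the bromo if the group on the other aromatic ring were changed.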